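This account rests on a few compounds, and the source may have more. Where it says the series, first, only, none or still open, it means among the compounds named here.

Compound 1 `Cc1ccccc1C(=O)Nc1ccc(S(=O)(=O)NC2CCN(C(=O)CCN)CC2)c2ccccc12` and compound 2 `Cc1ccccc1C(=O)Nc1ccc(S(=O)(=O)NC2CCN(C(=O)N3CCC3)CC2)c2ccccc12` share one core and differ only at a carbonyl carbon. In an assay on L1.2 cells for binding affinity to C-C chemokine receptor type 8 (Homo sapiens) (a lower number here means a stronger inhibitor, a higher number a weaker inhibitor), compound 1 gives 11.3 nM, whereas compound 2 gives 3.5 nM, so that a 3.2-fold lower number from compound 1 to compound 2 (0.51 log units; beyond the scatter). Within the data shown here, compound 2 therefore holds the lowest of the two numbers so far. Compound 3 `CCCC(=O)N1CCC(NS(=O)(=O)c2ccc(NC(=O)c3ccccc3C)c3ccccc23)C1` carries 1-(propylcarbonyl)pyrrolidin-3-yl in place of 1-((azetidin-1-yl)carbonyl)piperidin-4-yl on a sulfonamide nitrogen. Among the measured compounds shown here, the single measured step concerns a different group on the same side of the molecule, so it gives only a loose guide, and the ring change itself has no measured counterpart. A moderately higher number than for compound 2 is expected, namely a 2.9-fold higher number from compound 2 to compound 3 (0.46 log units; beyond the scatter), and compound 3 is estimated at 10 nM, with a range from 2.5 nM to 40 nM.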

Compound 3, inhibition constant: 34.3 nM
Estimate against measurement, compound 3: 3.4-fold (0.54 log units) below, within the range that was stated.
By their numbers in this assay, from the lowest: compound 2; then compound 1; then compound 3.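

In this assay, the group on the sulfonamide nitrogen clearly matters: 1-(propylcarbonyl)pyrrolidin-3-yl in place of 1-((azetidin-1-yl)carbonyl)piperidin-4-yl gives a 9.8-fold higher number from compound 2 to compound 3 (0.99 log units; beyond the scatter) in this series. Set against the 1-((2-aminoethyl)carbonyl)piperidin-4-yl group, it gives a 3.0-fold higher number from compound 1 to compound 3 (0.48 log units; beyond the scatter) and so ranks behind both earlier groups. No available evidence explains these differences.

Ring size and the group on the carbonyl change together here, so neither change can be credited alone. A piperidin-4-yl ring carrying the propylcarbonyl group, or a pyrrolidin-3-yl ring carrying the azetidin-1-yl carbonyl group, would separate the two.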